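The source may report more compounds than this note shows. Statements on the series, on what has been measured and on what is new or still open speak of the compounds shown alone.

Compound 1 `CCCC(=O)c1ccc(OCCCCOc2cccc(C(=O)O)c2C)c(C)c1O` gives 82.4% in an assay on HEK293 cells for positive allosteric modulation of metabotropic glutamate receptor 2 (Rattus norvegicus), read by thallium flux, with a stated time of 2.5 min; a higher number here means a larger maximal response, a lower number a smaller maximal response. Compound 2 `Cc1c(OCCCCOc2ccc(C(=O)C(C)C)c(O)c2C)cccc1C(=O)O` gives 66.9% in this assay. The change between them, (isopropyl in place of propyl on a carbonyl carbon), produced a number 15.5 percentage points lower from compound 1 to compound 2 (beyond the scatter).

Compound 3 `CCCC(=O)c1ccc(OCCCCOc2cc(C(=O)O)ccc2OC)c(C)c1O` gives 82.8% in this assay; the difference between the core of compound 3 and the core of compound 1 is not broken down here. Compound 4 `COc1ccc(C(=O)O)cc1OCCCCOc1ccc(C(=O)C(C)C)c(O)c1C` has not yet been measured in this assay. Going by the values given here, it differs from compound 3 by isopropyl in place of propyl on a carbonyl carbon, the same change as the one from compound 1 to compound 2, at the same kind of place.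

Since the earlier step was a number 15.5 percentage points lower from compound 1 to compound 2 (beyond the scatter), the step from compound 3 to compound 4 is expected to be a number 15.8 percentage points lower from compound 3 to compound 4 (beyond the scatter). Compound 4 is therefore estimated to give 67% in this assay, expected to fall between 55% and 80%.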

Compound 4, largest response reached (reported as percent of maximum), in percent of the reference or control that the assay uses: 66.6%
The estimate for compound 4 lay 0.4 percentage points above the measured number; measured number inside the range.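

Isopropyl in place of propyl on a carbonyl carbon again lowers the maximal response in this assay, giving a number 16.2 percentage points lower from compound 3 to compound 4 (beyond the scatter). The change carries from the core of compound 1 to the core of compound 3 with much the same size: the same change on two cores in this assay, a number 15.5 percentage points lower (beyond the scatter) from compound 1 to compound 2 and a number 16.2 percentage points lower (beyond the scatter) from compound 3 to compound 4, 0.7 percentage points apart, within the scatter of two such steps. Going by these compounds alone, this rests on only two pairs in a single assay, and it shows neither why the response falls nor that the step would hold on a core unlike these two.

The compounds shown leave open whether a cyclopropyl group or a longer chain such as butyl on the same carbonyl carbon would keep the response seen with propyl. They also leave open how a tetrazole in place of the carboxylic acid would alter this step.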